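Compound 3: fluoro in place of chloro

The source may report more compounds than this note shows. Statements on the series, on what has been measured and on what is new or still open speak of the compounds shown alone.

In an ADME assay on MT4 cells (Homo sapiens) for cytotoxicity, read by MTT assay, with a stated time of 5 days (a lower number here means that less compound is tolerated, a higher number that more compound is tolerated), compound 1 `COc1cc(-c2ccc(C#N)cc2)ccc1C(O)c1ccnc(Nc2ccc(C#N)cc2)n1` gives 13200 nM and compound 2 `N#Cc1ccc(Nc2nccc(C(O)c3ccc(-c4ccc(C#N)cc4)cc3Cl)n2)cc1` gives 7540 nM. For the measured compounds named here, these two values lie within the scatter of each other, so compound 2 stands level with the only other measured compound. Compound 3 `N#Cc1ccc(Nc2nccc(C(O)c3ccc(-c4ccc(C#N)cc4)cc3F)n2)cc1` is not yet measured. Its difference from compound 2 is fluoro in place of chloro on an aromatic carbon, with fluoro in place of chloro on an aromatic carbon. Going by the values given here, one measured step bears on this change: a 1.8-fold lower number from compound 1 to compound 2 (0.24 log units; within the scatter), with chloro in place of methoxy on an aromatic carbon. Among the compounds with values here, that step stays within the scatter, and no measured step involves fluoro. No shift beyond the scatter is therefore expected in this assay, and no direction can be supported. The estimated change is a 1.2-fold higher number from compound 2 to compound 3 (0.08 log units; within the scatter). For compound 3 the expected value is 9000 nM, with an estimated range of 4500 nM to 20000 nM.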

Compound 3, half-maximal cytotoxic concentration: 14300 nM
For compound 3 the middle estimate is 1.6-fold (0.20 log units) below the measured one; measured number inside the range.
By their numbers in this assay, from the lowest: compounds 2, 1 and 3 (each within the scatter of the next).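

In this assay, the position ortho to a large group and meta to a 4-cyanophenyl group has now been seen with methoxy, chloro and fluoro, and the three stand level: the data give a 1.9-fold higher number from compound 2 to compound 3 (0.28 log units; within the scatter) and a 1.1-fold higher number from compound 1 to compound 3 (0.03 log units; within the scatter), both within the scatter. Fluoro therefore adds a third group at this place without any step beyond the scatter, so among compounds 1, 2 and 3 the tolerated concentration does not separate these groups. No supporting measurement is available to explain this reading.

From the compounds shown here alone, whether an amine, a carboxylic acid or a longer chain such as butoxy at this place would give a step beyond the scatter remains open. All three compounds share the rest of the structure, so this reading applies only to that shared core.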